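From 4-iodophenyl to 4-ethoxyphenyl on a shared core

The source may hold more compounds than are shown below. What is called first, only, known or untested is meant among the compounds shown, and "the series" means these compounds.

Compound 1 `O=C1C(Nc2ccc(I)cc2)=CC(=O)c2c1nc1n2[C@H]2OC[C@@H](O)[C@H]2OC1` gives 3890 nM in a functional assay on MCF7 cells (Homo sapiens) for inhibition, read by sulforhodamine B assay (a lower number here means a stronger inhibitor, a higher number a weaker inhibitor), the lower of the two numbers in hand, though within the scatter of compound 2. Compound 2 `CCCc1ccc(NC2=CC(=O)c3nc4n(c3C2=O)[C@H]2OC[C@@H](O)[C@H]2OC4)cc1` gives 4660 nM in this assay. Compound 3 `O=C1C=C(NC2CCCCC2)C(=O)c2c1nc1n2[C@H]2OC[C@@H](O)[C@H]2OC1` reaches only the limit > 8000 nM in this assay. Within the data shown here, the one measured step, an at least 1.7-fold higher number from compound 2 to compound 3 (0.23 log units; that floor lies within the scatter), ends at that limit of > 8000 nM in this assay, at which 1 of the 3 values shown sits, and concerns the amine substituent, not the ring. Compound 4 `CCOc1ccc(NC2=CC(=O)c3c(nc4n3[C@H]3OC[C@@H](O)[C@H]3OC4)C2=O)cc1` is not yet measured; it differs from compound 1 by ethoxy in place of iodo on an aromatic carbon. Among the measured compounds shown here, no measured step covers this exchange on the ring. The author expects a shift of no size beyond the scatter, a 1.3-fold higher number from compound 1 to compound 4 (0.11 log units; within the scatter). Compound 4 is estimated at 5000 nM, between 2500 nM and 10000 nM.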

Compound 4, half-maximal inhibitory concentration: > 4000 nM
Compound 4: a limit, no number; the forecaster's own chance of this, stated with the estimate: 20%; the middle value does not contradict the limit.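

As far as these compounds go, the exchange of iodo for ethoxy on the aromatic carbon can be read only as a floor, an at least 1.0-fold higher number from compound 1 to compound 4 (0.01 log units; that floor lies within the scatter), so its true size stays unknown. It does show that ethoxy at this position gives no sign of a lower number than iodo in this assay. Compound 4 has a limit and not a number: the limit of > 4000 nM in this assay, at which 1 of the 4 values shown sits.

From the compounds shown here alone, how far compound 4 actually lies from compound 1 remains open. So does the effect of an amine or a carboxylic acid on this same aromatic carbon of the shared core.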